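Adding Fluorine to the Aminomethyl Coumarin Ester

A few compounds are considered here, and "the series" means these few. Any claim that something is new, unique, unknown or untested is made for them only; others in the source may bear on it.

Compound 3, `NCc1ccc2oc(=O)c(C(=O)Oc3ccccc3)cc2c1`, was tested in a functional assay on HT-1080 cells (Homo sapiens), read by transwell migration, with a stated time of 24 h, tested at 1 uM (a lower number here means a stronger effect, a higher number a weaker effect of the compound at the concentration tested), and gave 85.5%, the highest of the three numbers shown; compound 1, `O=C(Oc1ccccc1)c1cc2cc([N+](=O)[O-])ccc2oc1=O`, with 76.7% sits within the scatter of it, while compound 2, `O=C(Oc1cccc(F)c1)c1cc2cc([N+](=O)[O-])ccc2oc1=O`, with 53.6% lies beyond it. Compound 4, `NCc1ccc2oc(=O)c(C(=O)Oc3cccc(F)c3)cc2c1`, differs from compound 3 by one change: fluoro in place of hydrogen on an aromatic carbon. The same change is already known from a number 23.1 percentage points lower from compound 1 to compound 2 (beyond the scatter), a modest drop beyond the scatter. The step of a number 8.8 percentage points higher from compound 1 to compound 3 (within the scatter) shows that swapping the other group changed little. A comparable lowering is therefore expected here, a number 22.5 percentage points lower from compound 3 to compound 4 (beyond the scatter). Compound 4 is thus estimated at 63%, most likely between 46% and 80%.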

Compound 4, a percentage reported as activity, at one concentration (the size of the read-out at that concentration, not a potency): 45.3%
The estimate for compound 4 lay 17.7 percentage points above the measured number, outside the stated range (below it).
By their numbers in this assay, from the lowest: compounds 4 and 2 (each within the scatter of the next); then compounds 1 and 3 (each within the scatter of the next).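

In this assay, the phenyl to 3-fluorophenyl change also works on the aminomethyl core, giving a number 40.2 percentage points lower from compound 3 to compound 4 (beyond the scatter). Its size is not the same on both cores, and the step is larger here: the same change on two cores in this assay, a number 23.1 percentage points lower (beyond the scatter) from compound 1 to compound 2 and a number 40.2 percentage points lower (beyond the scatter) from compound 3 to compound 4, 17.1 percentage points apart, beyond the scatter of two such steps. With the fluoro group present, swapping nitro for aminomethyl gives a number 8.3 percentage points lower from compound 2 to compound 4 (within the scatter), and this step and the one without fluoro run in opposite directions: the same change on two cores in this assay, a number 8.8 percentage points higher (within the scatter) from compound 1 to compound 3 and a number 8.3 percentage points lower (within the scatter) from compound 2 to compound 4, 17.1 percentage points apart, beyond the scatter of two such steps.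

As far as these compounds go, how chloro or methoxy in the same place would compare stays open. So does whether the larger step would hold with a carboxylic acid in place of the aminomethyl.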